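The compounds below may be only part of what the source reports. "The series", "measured", "known", "first", "only" and "open" are said of these compounds alone.

Three compounds share one core and differ in the ring attached to it. Compound 1 `c1cncc(-c2ccccc2OCC2=NCCN2)c1` gives 158 nM in a functional assay for activation of Alpha-1D adrenergic receptor (Homo sapiens), read by calcium flux; on this read-out lower numbers stand for an effect already at smaller amounts and higher numbers for an effect only at larger amounts of compound. Compound 3 `c1c[nH]c(-c2ccccc2OCC2=NCCN2)c1` gives 6.31 nM in this assay, the lowest of the two numbers shown, and the only measured step between two numbers is a 25-fold lower number from compound 1 to compound 3 (1.40 log units; beyond the scatter). Compound 2 `Cc1cccnc1-c1ccccc1OCC1=NCCN1` reaches only < 100000 nM in this assay, which is a limit of the assay and not a number.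

Compound 4 `Cc1ccc(-c2ccccc2OCC2=NCCN2)s1` has not yet been measured in this assay. Its difference from compound 3 is 5-methylthiophen-2-yl in place of 1H-pyrrol-2-yl on an aromatic carbon. Among the compounds with values here, no measured step exchanges one five-membered ring for another, so the change stands without a direct precedent. Within the data shown here, the one step on record, a 25-fold lower number from compound 1 to compound 3 (1.40 log units; beyond the scatter), replaced a six-membered ring by 1H-pyrrol-2-yl and gave the lowest number seen, so a five-membered ring at this place has done well once. With 5-methylthiophen-2-yl the hydrogen-bond donor leaves and a hydrogen-bond acceptor enters; the data hold no measurement of what that is worth. A modest rise in the number is expected, and the expected step is a 7.9-fold higher number from compound 3 to compound 4 (0.90 log units; beyond the scatter). Compound 4 is estimated at 50 nM, with a range from 8 nM to 400 nM.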

Compound 4, half-maximal effective concentration: < 100000 nM
Compound 4: only a limit was reported; the forecaster's own chance of this, stated with the estimate: 5%; the middle value lies beyond the limit too.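

Compound 4 gives only a limit and not a number, so the steps to it from compound 3 and from compound 1 cannot be read. Compound 2 and compound 4 sit at the same value: the limit of < 100000 nM in this assay, at which 2 of the 4 values shown sit. The compounds shown leave open how far compound 4 lies from compound 3, and whether the thiophene ring or its methyl group matters more.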